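The source may hold more compounds than are shown below. What is called first, only, known or untested is meant among the compounds shown, and "the series" means these compounds.

For the measured compounds named here, compound 3 `Nc1ccccc1NC(=O)c1ccc(CSC(=S)N2CCN(c3cnccn3)CC2)cc1` gives 70.4% in a functional assay on HeLa cells (Homo sapiens) for antiproliferative activity, read by CCK-8 assay, with a stated time of 72 h, tested at 2 uM (on this read-out lower numbers stand for a weaker effect and higher numbers for a stronger effect at the one concentration tested), the highest of the three numbers measured so far. Compound 1 `Nc1ccccc1NC(=O)c1ccc(CSC(=S)N2CCN(c3cccnc3)CC2)cc1` gives 66.2% in this assay; the step of a number 4.2 percentage points higher from compound 1 to compound 3 (within the scatter) lies within the scatter, so the two cannot be ordered. Compound 2 `COc1ccc(N2CCN(C(=S)SCc3ccc(C(=O)Nc4ccccc4N)cc3)CC2)cc1` gives 39.4%, and the step of a number 31 percentage points higher from compound 2 to compound 3 (beyond the scatter) is large and beyond the scatter.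

Compound 4 `Nc1ccccc1NC(=O)c1ccc(CSC(=S)N2CCN(Cc3ccccc3)CC2)cc1` has not yet been measured in this assay. Its change from compound 3 is benzyl in place of pyrazin-2-yl on an amine nitrogen in a ring. The measured steps that bear on it are the two exchanges of the group on the ring nitrogen: the step of a number 26.8 percentage points lower from compound 1 to compound 2 (beyond the scatter) and the step of a number 31 percentage points higher from compound 2 to compound 3 (beyond the scatter). In both, the ring with hetero atoms gave the higher number and the ring of carbon only gave the lower one. Since benzyl likewise brings a ring of carbon only, a drop of similar size is expected, as the estimated step of a number 26.4 percentage points lower from compound 3 to compound 4 (beyond the scatter) shows. Compound 4 is therefore estimated to give 44%, within a range from 26% to 62%.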

Compound 4, a percentage reported as inhibition, at one concentration (the size of the read-out at that concentration, not a potency): 20.6%
Beside the measured number, compound 4's estimate is 23.4 percentage points above it; the measured number lies below the stated range.
By their numbers in this assay, from the lowest: compound 4; then compound 2; then compounds 1 and 3 (each within the scatter of the next).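

In this assay, benzyl on the ring nitrogen gives the lowest number of the four compounds, with a number 49.8 percentage points lower from compound 3 to compound 4 (beyond the scatter) and a number 45.6 percentage points lower from compound 1 to compound 4 (beyond the scatter), both large. The two groups with a ring of carbon only are also not equivalent at this position, as a number 18.8 percentage points lower from compound 2 to compound 4 (beyond the scatter) shows, so having such a ring does not by itself set the level of the read-out. No measurement on hand explains these differences.

Benzyl differs from pyrazin-2-yl both in its ring atoms and in its added carbon, and the compounds shown do not separate these two changes. A pyridin-3-ylmethyl group would keep the ring nitrogen with that added carbon, while an unsubstituted phenyl would remove the carbon and the methoxy group, so either could help tell these contributions apart.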